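The compounds below may be only part of what the source reports. "The series", "measured", "known", "first", "only" and "open" are said of these compounds alone.

Compound 1, `COc1cc2c(Oc3ccc(NC(=O)c4nn(-c5ccccc5)c(=O)c5ccccc45)cc3F)ccnc2cc1OCCCN1CCCC1`, gives 980 nM in a functional assay on HT-29 cells (Homo sapiens) for cytotoxicity, read by MTT assay, with a stated time of 72 h; on this read-out lower numbers stand for stronger inhibition and higher numbers for weaker inhibition. Compound 2, `COc1cc2c(Oc3ccc(NC(=O)c4nn(-c5ccccc5)c(=O)c5ccccc45)cc3F)ccnc2cc1OCCCN1CCN(C)CC1`, gives 1140 nM. Compound 3, `COc1cc2c(Oc3ccc(NC(=O)c4nn(-c5ccc(F)cc5)c(=O)c5ccccc45)cc3F)ccnc2cc1OCCCN1CCN(C)CC1`, gives 320 nM.

Among these three numbers compound 2 stands highest, though only just: a 1.2-fold higher number from compound 1 to compound 2 (0.07 log units; within the scatter), whereas a 3.6-fold lower number from compound 2 to compound 3 (0.55 log units; beyond the scatter).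

Compound 4, `COc1cc2c(Oc3ccc(NC(=O)c4nn(-c5ccccc5)c(=O)c5ccccc45)cc3F)ccnc2cc1OCCCN1CCCCC1`, differs from compound 2 by piperidin-1-yl in place of 4-methylpiperazin-1-yl on a saturated chain carbon, three bonds along the chain from an oxygen on an aromatic ring. Going by the values given here, the one measured step that bears on this place in the molecule is the earlier exchange of amines on the same chain, a 1.2-fold higher number from compound 1 to compound 2 (0.07 log units; within the scatter), which stayed within the scatter. On that basis no step beyond the scatter is expected in this assay, and the expected change is a 1.1-fold lower number from compound 2 to compound 4 (0.06 log units; within the scatter).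

Compound 4 is therefore estimated at 1000 nM, with a range from 500 nM to 2200 nM.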

Compound 4, half-maximal inhibitory concentration: 1310 nM
Compound 4: the middle estimate sits 1.3-fold (0.12 log units) below what was measured; low and high end bracket the measured number.
By their numbers in this assay, from the lowest: compound 3; then compounds 1, 2 and 4 (each within the scatter of the next).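

Piperidin-1-yl joins pyrrolidin-1-yl and 4-methylpiperazin-1-yl on this chain without any step beyond the scatter in this assay: a 1.1-fold higher number from compound 2 to compound 4 (0.06 log units; within the scatter), and a 1.3-fold higher number from compound 1 to compound 4 (0.13 log units; within the scatter). The second ring nitrogen and the methyl of 4-methylpiperazin-1-yl therefore make no readable difference to this number. Nothing available explains this tolerance.

On these data alone, whether morpholine, an open-chain amine such as dimethylamino, or a shorter or longer chain would also leave the number within the scatter stays open. So does whether the fluoro step seen with compound 3 would recur with piperidin-1-yl on the chain.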